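A few compounds are considered here, and "the series" means these few. Any claim that something is new, unique, unknown or untested is made for them only; others in the source may bear on it.

Measured so far:
- compound 1, `CCCN(CC1CC1)c1cc(C)nc2c(-c3ncc(Cl)cc3Cl)c(C)nn12`: 3.9 nM
- compound 2, `CCCN(CCC)c1cc(C)nc2c(-c3ncc(C)cc3[N+](=O)[O-])c(C)nn12`: 14 nM
- compound 3, `CCCN(CCC)c1cc(C)nc2c(-c3ncc(N)cc3C)c(C)nn12`: 85 nM

The measurement here is an assay on isolated protein for binding affinity to corticotropin-releasing factor receptor 1 (Homo sapiens); a lower number here means a stronger inhibitor, a higher number a weaker inhibitor. Of the three compounds, compound 3 gives the highest number, 85 nM, and so binds the weakest. The gap to compound 2, which gives 14 nM, and the larger gap to compound 1, which gives 3.9 nM, both lie well beyond the scatter of repeated measurements.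

Compound 4, `CCCN(CCC)c1cc(C)nc2c(-c3ncc(Cl)cc3C)c(C)nn12`, differs from compound 3 in one place: chloro in place of amino on an aromatic carbon. The rest of the molecule, including the two propyl chains on the nitrogen and the shared core, is unchanged. Among the compounds with values here, since no pair of the measured compounds differs in just this one place, no measured step shows directly what the swap does. Compound 1, however, carries chloro on its pyridine ring and gives the lowest number of the three, while the weakest binder, compound 3, carries amino. On that basis compound 4 is expected to bind more strongly than compound 3, with an estimated step of an 8.5-fold lower number from compound 3 to compound 4 (0.93 log units; beyond the scatter) in this assay. Compound 4 is estimated at 10 nM, within a range of 3 nM to 35 nM.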

Compound 4, inhibition constant: 6.7 nM
The estimate for compound 4 lay 1.5-fold (0.17 log units) above the measured number; the measured number falls inside the stated range.
By their numbers in this assay, from the lowest: compounds 1 and 4 (each within the scatter of the next); then compound 2; then compound 3.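

Putting chloro in place of amino on this aromatic carbon, with the rest of the molecule unchanged, gives a 13-fold lower number from compound 3 to compound 4 (1.10 log units; beyond the scatter) in this assay. Within the data shown here, none of the earlier compounds formed a pair differing in one place, so this is the first direct sign that the group at this position strongly affects the measured number. The swap removes the hydrogen-bond donor and acceptor counted for amino, but nothing here shows what lies behind the size of the step.

As far as these compounds go, it remains open whether the step reflects losing amino, gaining chloro, or both. Nor do the compounds shown tell how other groups on this same carbon, such as fluoro, methoxy or a nitrile, would compare with chloro and amino when the rest of the molecule stays the same.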